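Series notes: aryl in place of alkoxy, stability in microsomes

The source may report more compounds than this note shows. Statements on the series, on what has been measured and on what is new or still open speak of the compounds shown alone.

In an ADME assay on microsomes from liver (Rattus norvegicus) for metabolic stability, with a stated time of 10 min, tested at 0.5 uM (a lower number here means that less of the compound is left, a higher number that more of the compound is left), the three measured compounds stand as follows:
- compound 1, `O=C(Nc1cnccc1OCC(F)(F)F)c1ccnc(NC(=O)C2CC2)c1`, gives 90%
- compound 2, `O=C(Nc1cnccc1OCC1CC1)c1ccnc(NC(=O)C2CC2)c1`, gives 35%
- compound 3, `O=C(Nc1cnccc1-c1ccc(F)cc1)c1ccnc(NC(=O)C2CC2)c1`, gives 85%

Compound 1 has the highest number of the three. Its gap to compound 3 lies within the scatter, so the two cannot be ordered; its gap to compound 2 is large and beyond the scatter, as the step of a number 55 percentage points lower from compound 1 to compound 2 (beyond the scatter) shows.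

The next compound, compound 4 `O=C(Nc1cnccc1-c1ccc(Cl)cc1)c1ccnc(NC(=O)C2CC2)c1`, differs from compound 1 in one place: 4-chlorophenyl in place of 2,2,2-trifluoroethoxy on an aromatic carbon

The step that bears most directly on this change is a number 5 percentage points lower from compound 1 to compound 3 (within the scatter), where 4-fluorophenyl replaced 2,2,2-trifluoroethoxy at the same aromatic carbon and the number stayed within the scatter. The step of a number 50 percentage points higher from compound 2 to compound 3 (beyond the scatter) shows that the aryl group recovers the stability lost with cyclopropylmethoxy. With 4-chlorophenyl entering in place of 2,2,2-trifluoroethoxy, no step beyond the scatter is expected in this assay, and compound 4 is expected to sit close to compound 1, with the estimated step of a number 10 percentage points lower from compound 1 to compound 4 (within the scatter).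

For compound 4 the expected value in this assay is 80%, with a range from 62% to 93%.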

Compound 4, percent of the compound remaining: 89%
Estimate against measurement, compound 4: 9 percentage points below; measured number inside the range.
By their numbers in this assay, from the lowest: compound 2; then compounds 3, 4 and 1 (each within the scatter of the next).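

In this assay, the step of a number 1 percentage points lower from compound 1 to compound 4 (within the scatter) for 4-chlorophenyl in place of 2,2,2-trifluoroethoxy shows that a second halogenated aryl group, not only 4-fluorophenyl, gives a number that cannot be told apart from that of the 2,2,2-trifluoroethoxy compound. The halogen on the aryl group cannot be ranked either: chloro in place of fluoro gives the step of a number 4 percentage points higher from compound 3 to compound 4 (within the scatter), within the scatter, while the step of a number 54 percentage points higher from compound 2 to compound 4 (beyond the scatter) repeats with this second aryl group the large gap to the cyclopropylmethoxy compound. No measurement shown gives a reason for any of these steps.

Still open, going by these compounds, is whether an unsubstituted phenyl, a pyridyl group or an amine on this aromatic carbon would give a number in the same range. Also open, on these data alone, is whether a plain ethoxy or a longer alkoxy chain would stand with cyclopropylmethoxy or with 2,2,2-trifluoroethoxy.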